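Adding a Methyl to the Phenyl: Expected Cytotoxicity

A few compounds are considered here, and "the series" means these few. Any claim that something is new, unique, unknown or untested is made for them only; others in the source may bear on it.

compound 1 `Nc1ccc(Nc2nc3ccccc3nc2S(=O)(=O)c2ccccc2)cc1` — in a functional assay on KB cells (Homo sapiens) for cytotoxicity, read by MTT assay, with a stated time of 72 h (a higher number here means a weaker inhibitor, a lower number a stronger inhibitor), compound 1 gives 3400 nM.
compound 2 `O=S(=O)(c1ccccc1)c1nc2ccccc2nc1Nc1ccc(C(F)(F)F)cc1` — in this assay compound 2 reaches only a limit of the assay, > 50000 nM, which is not a number.

Going by the values given here, compound 1 therefore holds the only actual number among the measured compounds; the other value is a limit (the limit of > 50000 nM in this assay, at which 1 of the 2 values shown sits). Compound 3 `Cc1ccc(S(=O)(=O)c2nc3ccccc3nc2Nc2ccc(N)cc2)cc1` differs from compound 1 by methyl in place of hydrogen on an aromatic carbon. Among the compounds with values here, the single measured step, an at least 14-fold higher number from compound 1 to compound 2 (1.16 log units; beyond the scatter), alters the amino group on a different ring from the phenyl that becomes 4-methylphenyl in compound 3, so it does not bear directly on this change. Within the data shown here, with no measured step touching that phenyl, the expectation is a small change, most likely within the scatter, in either direction. The estimate for compound 3 in this assay is 3500 nM, with a range from 1500 nM to 8500 nM. This expected value means a step of a 1.0-fold higher number from compound 1 to compound 3 (0.01 log units; within the scatter).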

Compound 3, half-maximal inhibitory concentration: 5630 nM
Compound 3: the middle estimate sits 1.6-fold (0.21 log units) below what was measured; low and high end bracket the measured number.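

In this assay, going by these compounds alone, going from phenyl to 4-methylphenyl gives a 1.7-fold higher number from compound 1 to compound 3 (0.22 log units; within the scatter), the first measured step at this ring of the molecule. A single added carbon at this place, on an aromatic carbon para to a large group, therefore leaves a measurable cytotoxic effect in place, and compound 3 cannot be told apart from compound 1 within the usual scatter. Nothing measured here bears on the reason for this outcome.

The compounds shown leave open whether the same place also accepts something other than a methyl, such as a chlorine atom, a methoxy group, a carboxylic acid or a longer chain like propyl. Also open, from the compounds shown here alone, is how a hydroxyl or a methylamino group would read in place of the amino group of compound 1.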